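A few compounds are considered here, and "the series" means these few. Any claim that something is new, unique, unknown or untested is made for them only; others in the source may bear on it.

In a functional assay for antagonist activity at transient receptor potential cation channel subfamily V member 1 (Homo sapiens), read by FLIPR (on this read-out lower numbers stand for stronger inhibition and higher numbers for weaker inhibition), compound 1 `CC(C)(C)c1ccc(NC(=O)c2ccc(-c3ccccn3)cc2)cc1` gives 11 nM, compound 2 `CC(C)(C)c1ccc(NC(=O)c2ccc(-c3ncccc3F)cc2)cc1` gives 3 nM, and compound 3 `CCS(=O)(=O)Nc1cccnc1-c1ccc(C(=O)Nc2ccc(C(C)(C)C)cc2)cc1` gives 49 nM, the highest of the three numbers. Compound 4 `CC(C)(C)c1ccc(NC(=O)c2ccc(-c3ncccc3-c3ncc[nH]3)cc2)cc1` differs from compound 3 by 1H-imidazol-2-yl in place of (ethylsulfonyl)amino on an aromatic carbon. Among the measured compounds shown here, two measured steps touch this position: a 4.5-fold higher number from compound 1 to compound 3 (0.65 log units; beyond the scatter) and a 16-fold higher number from compound 2 to compound 3 (1.21 log units; beyond the scatter), both showing that the group now leaving pushed the number up, while a 3.7-fold lower number from compound 1 to compound 2 (0.56 log units; beyond the scatter) shows fluoro there pulling it down. For the measured compounds named here, no measured compound carries a ring at this position, so the new group has no direct precedent. The step of a 2.5-fold lower number from compound 3 to compound 4 (0.39 log units; beyond the scatter) is expected to be a modest fall, because the group that raised the number in a 4.5-fold higher number from compound 1 to compound 3 (0.65 log units; beyond the scatter) is removed. Compound 4 is therefore expected to give about 20 nM, within 5 nM to 80 nM.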

Compound 4, half-maximal inhibitory concentration: 3670 nM
Compound 4: the middle estimate sits 180-fold (2.26 log units) below what was measured; measured number above the stated range.
By their numbers in this assay, from the lowest: compound 2; then compound 1; then compound 3; then compound 4.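

In this assay the 1H-imidazol-2-yl group takes the number far outside the range set at this position by hydrogen, fluoro and (ethylsulfonyl)amino, which spanned only (a 16-fold higher number from compound 2 to compound 3 (1.21 log units; beyond the scatter)). The rise holds against all three neighbours (a 75-fold higher number from compound 3 to compound 4 (1.87 log units; beyond the scatter); a 330-fold higher number from compound 1 to compound 4 (2.52 log units; beyond the scatter); a 1200-fold higher number from compound 2 to compound 4 (3.09 log units; beyond the scatter)), so this place, ortho to a large group, does not accept every substituent alike. Nothing available here bears on what lies behind this rise. From the compounds shown here alone, whether it belongs to this particular ring or to rings at this place generally remains open. A phenyl ring, a pyridine ring or an open-chain amine here would help to separate those readings.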